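The compounds below may be only part of what the source reports. "The series", "measured", "known", "first", "only" and "open" are said of these compounds alone.

Measured in a functional assay on HCT-116 cells (Homo sapiens) for cytotoxicity, read by MTT assay, with a stated time of 72 h; on this read-out higher numbers stand for weaker inhibition and lower numbers for stronger inhibition:

- compound 1 `O=C(Nc1ccc(C(=O)NO)cc1)Nc1ccc([N+](=O)[O-])cc1` gives 28400 nM
- compound 2 `O=C(CCc1ccc(NC(=O)Nc2ccc(Cl)cc2)cc1)NO` gives 17900 nM
- compound 3 `COc1ccc(NC(=O)Nc2ccc(CCC(=O)NO)cc2)cc1` gives 31000 nM

Compound 3 stands within the scatter of both compound 1 and compound 2, so these numbers set no order among the three. The next compound to be measured, compound 4 `O=C(CCc1ccc(NC(=O)Nc2ccc([N+](=O)[O-])cc2)cc1)NO`, has nitro in place of methoxy on an aromatic carbon. Within the data shown here, no measured step makes this exact exchange. The closest evidence is a 1.7-fold higher number from compound 2 to compound 3 (0.24 log units; within the scatter), a change of methoxy in place of chloro at the same kind of position. Compound 1 also carries nitro, on a different core, and gives 28400 nM. Because that one step is only a 1.7-fold higher number from compound 2 to compound 3 (0.24 log units; within the scatter), no shift beyond the scatter is expected in this assay, and no direction is firmly indicated. The expected step is a 1.3-fold lower number from compound 3 to compound 4 (0.13 log units; within the scatter). The estimated value for compound 4 is 23000 nM. The expected range for compound 4 runs from 11000 nM to 46000 nM.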

Compound 4, half-maximal inhibitory concentration: 6370 nM
For compound 4 the middle estimate is 3.6-fold (0.56 log units) above the measured one; measured number outside the range, below it.
By their numbers in this assay, from the lowest: compound 4; then compounds 2, 1 and 3 (each within the scatter of the next).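

In this assay this position, an aromatic carbon para to a large group, now shows a shift beyond the scatter: nitro in place of methoxy gives a step (a 4.9-fold lower number from compound 3 to compound 4 (0.69 log units; beyond the scatter)), and nitro in place of chloro gives another (a 2.8-fold lower number from compound 2 to compound 4 (0.45 log units; beyond the scatter)), whereas methoxy in place of chloro had stayed within it (a 1.7-fold higher number from compound 2 to compound 3 (0.24 log units; within the scatter)). The same nitro group also reads differently on the two cores, with 2-(hydroxycarbamoyl)ethyl in place of hydroxycarbamoyl giving a further step beyond the scatter (a 4.5-fold lower number from compound 1 to compound 4 (0.65 log units; beyond the scatter)). Nothing shown here bears on the reason for these steps.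

The compounds shown leave open whether a nitrile or a trifluoromethyl group at this place would give a similar number to nitro. They also leave open how a longer chain carrying the hydroxycarbamoyl group would read on the shared core.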